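The compounds below may be only part of what the source reports. "The series", "measured", "known", "first", "only" and "open" are said of these compounds alone.

Measured in a functional assay on MCF7 cells (Homo sapiens) for inhibition, read by MTT assay, with a stated time of 72 h; a lower number here means a stronger inhibitor, a higher number a weaker inhibitor:
- Compound 1 `CC(C)[C@H](NC(=O)c1cc(Cl)ccc1OCCNC(=O)O)C(=O)Nc1ccc([N+](=O)[O-])cc1Cl`: > 10000 nM, a limit
- Compound 2 `CC(C)[C@H](NC(=O)c1cc(Cl)ccc1OCCNC(=O)OC(C)(C)C)C(=O)Nc1ccc(C(F)(F)F)cc1Cl`: > 10000 nM, a limit
- Compound 3 `CC(C)[C@H](NC(=O)c1cc(Cl)ccc1OCCN)C(=O)Nc1ccc(C(F)(F)F)cc1Cl`: > 10000 nM, a limit

Compound 2 has no numerical value, and its entry of > 10000 nM is a limit. The other two compounds offer no number to compare it with, as the whole set stands at the limit of > 10000 nM in this assay, at which 3 of the 3 values shown sit.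

Compound 4 `CC(C)[C@H](NC(=O)c1cc(Cl)ccc1OCCNC(=O)OC(C)(C)C)C(=O)Nc1ccc(F)c(F)c1` has not yet been measured. It differs from compound 2 by 3,4-difluorophenyl in place of 2-chloro-4-(trifluoromethyl)phenyl on an amide-type nitrogen, with 3,4-difluorophenyl in place of 2-chloro-4-(trifluoromethyl)phenyl on an amide-type nitrogen.

Among the compounds with values here, only one measured step is available, a step that the two limits leave unreadable from compound 2 to compound 3. It lies at a different place in the structure and has no readable size, so it gives neither a size nor a direction for this change. The expected change is therefore none beyond the scatter in this assay, an estimated step that the limit leaves unreadable from compound 2 to compound 4. The assay will most likely report another limit. For compound 4 the estimated value is about 12000 nM, with an expected range from 4000 nM to 40000 nM.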

Compound 4, half-maximal inhibitory concentration: > 10000 nM
Compound 4 was reported as a limit; the forecaster's own chance of this, stated with the estimate: 75%; the middle value lies beyond the limit too.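

No step can be read from compound 2 to compound 4, since both entries are limits: the limit of > 10000 nM in this assay, at which 4 of the 4 values shown sit.

The compounds shown leave open how strongly any of them inhibits, and which change to the shared core, if any, would give a measurable value.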